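The compounds below may be only part of what the source reports. "The series", "measured", "known", "first", "only" and "open" are said of these compounds alone.

In a functional assay on A549 cells (Homo sapiens) for inhibition, read by sulforhodamine B assay (on this read-out lower numbers stand for stronger inhibition of growth and higher numbers for weaker inhibition of growth), three compounds built on a shared core have been measured so far. Compound 1 `Oc1cccc2[nH]c(-c3ccc(-c4ccc(-c5ccccc5)cc4)cc3)nc12` carries hydrogen at the aromatic carbon that varies and gives 8320 nM. Compound 2 `Oc1cccc2[nH]c(-c3ccc(-c4ccc(-c5ccc(C(F)(F)F)cc5)cc4)cc3)nc12` carries trifluoromethyl there and gives 3610 nM. Compound 3 `Oc1cccc2[nH]c(-c3ccc(-c4ccc(-c5ccc(OC(F)(F)F)cc5)cc4)cc3)nc12` carries trifluoromethoxy and gives 190 nM, the lowest of the three numbers, with its steps to both others beyond the scatter.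

The next compound, compound 4 `CN(C)c1ccc(-c2ccc(-c3ccc(-c4nc5c(O)cccc5[nH]4)cc3)cc2)cc1`, has dimethylamino in place of trifluoromethoxy on an aromatic carbon. Within the data shown here, no measured compound carries dimethylamino, so its own effect is unknown, and only indirect evidence is available. Adding trifluoromethyl gave only a 2.3-fold lower number from compound 1 to compound 2 (0.36 log units; beyond the scatter), a modest change. Adding trifluoromethoxy gave a 44-fold lower number from compound 1 to compound 3 (1.64 log units; beyond the scatter), a large one. Swapping one for the other gave a 19-fold lower number from compound 2 to compound 3 (1.28 log units; beyond the scatter), also large. The low number of compound 3 has thus appeared only with trifluoromethoxy, and that group leaves in compound 4. A large move back toward the other two numbers is therefore expected in this assay. The expected step is a 13-fold higher number from compound 3 to compound 4 (1.12 log units; beyond the scatter). The estimated value for compound 4 is 2500 nM, with an expected range from 500 nM to 9000 nM.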

Compound 4, concentration for 50% growth inhibition: 7100 nM
Beside the measured number, compound 4's estimate is 2.8-fold (0.45 log units) below it, and the stated range covers the measured number.
By their numbers in this assay, from the lowest: compound 3; then compounds 2, 4 and 1 (each within the scatter of the next, the first and the last beyond it).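

In this assay, dimethylamino in place of trifluoromethoxy at this position gives a 37-fold higher number from compound 3 to compound 4 (1.57 log units; beyond the scatter) and so removes nearly all of the gain that set compound 3 apart, even though the two groups have the same counts of hydrogen-bond donors and acceptors and neither carries a net charge. Compound 4 also cannot be told apart from the other two compounds, with a 2.0-fold higher number from compound 2 to compound 4 (0.29 log units; within the scatter) and a 1.2-fold lower number from compound 1 to compound 4 (0.07 log units; within the scatter), so among the four groups at this position (hydrogen, trifluoromethyl, dimethylamino and trifluoromethoxy) only trifluoromethoxy stands out, and the position does not respond to just any substituent. Nothing measured here explains why trifluoromethoxy differs from the other groups.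

The compounds shown leave open whether the low number belongs to trifluoromethoxy alone or would also appear with close relatives such as methoxy, difluoromethoxy or a longer ether chain. They also leave open how a halogen such as chlorine, or a smaller amine such as a primary amino group, would behave at this position.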